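The source may hold more compounds than are shown below. What is called first, only, known or untested is meant among the compounds shown, and "the series" means these compounds.

Measured so far in a functional assay on HeLa cells (Homo sapiens) for cytotoxicity, read by MTT assay, with a stated time of 72 h, tested at 10 uM; on this read-out higher numbers stand for more inhibition of growth at the one concentration tested and lower numbers for less inhibition of growth:
compound 1 `N/C(=N\NC(=S)N1CCCCCC1)c1ccccn1` gives 67.4%;
compound 2 `N/C(=N\NC(=S)N1CCSCC1)c1ccccn1` gives 54.5%;
compound 3 `N/C(=N\NC(=S)N1CCSCC1)c1ccc(F)cn1` gives 70.5%.

Compound 2 and compound 3 share a core and differ in one place, (fluoro in place of hydrogen on an aromatic carbon), and that change gave a number 16 percentage points higher from compound 2 to compound 3 (beyond the scatter). Compound 1 carries a different core; how its core differs from that of compound 2 is not broken down here, and its value lies above that of compound 2. The unmeasured compound 4 `N/C(=N\NC(=S)N1CCCCCC1)c1ccc(F)cn1` arises from compound 1 by fluoro in place of hydrogen on an aromatic carbon, the same change as that from compound 2 to compound 3. Because that change gave a number 16 percentage points higher from compound 2 to compound 3 (beyond the scatter), a rise of similar size is expected here as well. The read-out cannot exceed complete inhibition, so a somewhat smaller step is estimated, a number 9.6 percentage points higher from compound 1 to compound 4 (within the scatter). Compound 4 is therefore expected at 77%, between 63% and 90%.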

Compound 4, percent growth inhibition at one concentration: 83.2%
The estimate for compound 4 lay 6.2 percentage points below the measured number; measured number inside the range.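

In this assay, fluoro in place of hydrogen on an aromatic carbon gave a number 15.8 percentage points higher from compound 1 to compound 4 (beyond the scatter), and this step matches the earlier one on the other core: the same change on two cores in this assay, a number 16 percentage points higher (beyond the scatter) from compound 2 to compound 3 and a number 15.8 percentage points higher (beyond the scatter) from compound 1 to compound 4, 0.2 percentage points apart, within the scatter of two such steps. So, on these two cores, the change carried over with much the same size, and the core made no visible difference to the step. Going by these compounds alone, this rests on only two pairs of compounds at a single concentration, so it does not show that the step would hold on a further core, and it does not explain why the number rises.

The compounds shown leave open whether chloro, a methoxy group or an amine on that same aromatic carbon would give a step of similar size. They also leave open what fluoro would do on another carbon of the ring.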